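The source may hold more compounds than are shown below. What is called first, only, known or untested is meant among the compounds shown, and "the series" means these compounds.

Measured compounds in a functional assay on J774 cells (Mus musculus) for cytotoxicity, read by resazurin assay, with a stated time of 72 h; a higher number here means a weaker inhibitor, a lower number a stronger inhibitor:
compound 1, `O=S(=O)(Nc1cccc(CO)c1)c1ccc(-c2ccccc2)cc1`, gives 2200 nM;
compound 2, `O=S(=O)(Nc1cccc(CO)c1)c1ccc(-c2ccc(Br)cc2)cc1`, gives 2500 nM;
compound 3, `Cc1ccc(-c2ccc(S(=O)(=O)Nc3cccc(CO)c3)cc2)cc1`, gives 1200 nM.

Compound 2 differs from compound 1 by bromo in place of hydrogen on an aromatic carbon, and this step is a 1.1-fold higher number from compound 1 to compound 2 (0.06 log units; within the scatter). Compound 3 differs from compound 1 by methyl in place of hydrogen on an aromatic carbon, a step of a 1.8-fold lower number from compound 1 to compound 3 (0.26 log units; within the scatter). Compound 3 stands against compound 2 at a 2.1-fold lower number from compound 2 to compound 3 (0.32 log units; beyond the scatter). Compound 2 has the highest number of the three, though its gap to compound 1 is within the scatter.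

Compound 4, `Cc1ccc(CO)cc1NS(=O)(=O)c1ccc(-c2ccc(Br)cc2)cc1`, has not been measured in this assay. It differs from compound 2 by methyl in place of hydrogen on an aromatic carbon. The cores of the two pairs differ by bromo in place of hydrogen on an aromatic carbon. The place of the new methyl is not the same: in compound 3 it is para to a large group, in compound 4 it is ortho to a large group and para to a hydroxymethyl group, so this is the same kind of change rather than the same change. Among the measured compounds shown here, a step of similar size or smaller than the one from compound 1 to compound 3 is expected from compound 2 to compound 4, namely a 1.3-fold lower number from compound 2 to compound 4 (0.12 log units; within the scatter), resting on the single measured precedent a 1.8-fold lower number from compound 1 to compound 3 (0.26 log units; within the scatter). Compound 4 is therefore estimated at 1900 nM, between 900 nM and 4500 nM.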

Compound 4, half-maximal inhibitory concentration: > 5000 nM
Compound 4: no number, only a limit; the forecaster's own chance of this, stated with the estimate: 5%; middle value at least 2.6-fold (0.42 log units) from the limit.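

In this assay compound 4 gives > 5000 nM, which is a limit of the assay and not a number. On the core of compound 2, methyl in place of hydrogen gives an at least 2.0-fold higher number from compound 2 to compound 4 (0.30 log units; that floor lies within the scatter), and this does not agree with the same kind of change on the core of compound 1: the same change on two cores in this assay, a 1.8-fold lower number (0.26 log units; within the scatter) from compound 1 to compound 3 and an at least 2.0-fold higher number (0.30 log units; that floor lies within the scatter) from compound 2 to compound 4, at least 3.6-fold (0.56 log units) apart, beyond the scatter of two such steps. This shows that the earlier step cannot simply be carried from one core to the other in this series, but it does not show whether the core or the place of the methyl makes the difference, since the methyl in compound 4, ortho to a large group and para to a hydroxymethyl group, does not stand where it does in compound 3.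

From the compounds shown here alone, it remains open how a methyl in that same place would behave on the core of compound 1, and how far compound 4 lies past its limit. Also open, going by these compounds, is what a methoxy group or an amine in that place, or a carboxylic acid instead of the hydroxymethyl group, would do.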